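Swapping isopropyl for phenyl: what to expect

The source may report more compounds than this note shows. Statements on the series, on what has been measured and on what is new or still open speak of the compounds shown alone.

Measured so far in a functional assay on U-373MG ATCC cells (Homo sapiens) for inhibition, read by MTT assay, with a stated time of 72 h; on this read-out higher numbers stand for weaker inhibition and lower numbers for stronger inhibition
Compound 1 `CC1(C)CC(NC(=S)Nc2ccc(C#N)cc2)c2cc(Cl)ccc2O1` gives 10000 nM
Compound 2 `CC(C)NC(=S)NC1CC(C)(C)Oc2ccc(Cl)cc21` gives 57000 nM
Compound 3 `CC(C)NC(=O)NC1CC(C)(C)Oc2ccc(Cl)cc21` gives 62000 nM

Compound 2 sits level with compound 3, and its number is well above that of compound 1. The unmeasured compound 4 `CC1(C)CC(NC(=S)Nc2ccccc2)c2cc(Cl)ccc2O1` differs from compound 2 by having phenyl in place of isopropyl on an amide-type nitrogen. The closest guide is a 5.7-fold higher number from compound 1 to compound 2 (0.76 log units; beyond the scatter) for isopropyl in place of 4-cyanophenyl, read here in reverse. The step of a 1.1-fold higher number from compound 2 to compound 3 (0.04 log units; within the scatter) concerns another place and says little. Within the data shown here, no measured compound carries plain phenyl, so only part of that reversed step is expected. An expected step of a 2.9-fold lower number from compound 2 to compound 4 (0.45 log units; beyond the scatter) in this assay would point toward stronger inhibition. For compound 4 the estimated value is 20000 nM with an expected range of 8000 nM to 50000 nM here.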

Compound 4, half-maximal inhibitory concentration: 46000 nM
Compound 4: the middle estimate sits 2.3-fold (0.36 log units) below what was measured; low and high end bracket the measured number.
By their numbers in this assay, from the lowest: compound 1; then compounds 4, 2 and 3 (each within the scatter of the next).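

In this assay, phenyl in place of isopropyl on an amide-type nitrogen gives only a small change (a 1.2-fold lower number from compound 2 to compound 4 (0.09 log units; within the scatter)), so adding a plain aromatic ring at this position does not reproduce the stronger inhibition of compound 1. Hydrogen in place of cyano on an aromatic carbon gives the larger change (a 4.6-fold higher number from compound 1 to compound 4 (0.66 log units; beyond the scatter)), which ties the advantage of compound 1 to its cyano group rather than to the phenyl ring alone. No supporting data explain this difference.

As far as these compounds go, whether a nitro group or a methoxy group on that phenyl could stand in for cyano remains open.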